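The compounds below may be only part of what the source reports. "The series", "measured", "known", "first", "only" and "open" are said of these compounds alone.

Measured compounds in an assay on CHO cells for displacement of a labelled ligand from adenosine receptor A3 (Homo sapiens), read by scintillation counting, with a stated time of 45 min, in the presence of a further agent that is not named here; on this read-out higher numbers stand for weaker inhibition and lower numbers for stronger inhibition:

compound 1 `CCCn1c(=O)[nH]c2nc(-c3ccc(S(=O)(=O)N4CCN(c5cccc(Br)c5)CC4)cc3)[nH]c2c1=O` — in this assay compound 1 gives > 1000 nM, a limit of the assay and not a number.
compound 2 `CCCn1c(=O)[nH]c2nc(-c3ccc(S(=O)(=O)N4CCN(c5ccc(C)cc5)CC4)cc3)[nH]c2c1=O` — in this assay compound 2 gives > 1000 nM, again a limit of the assay and not a number.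

For the measured compounds named here, compound 2 therefore stands only at a limit; the one other value shown is a limit as well, and both sit at the limit of > 1000 nM in this assay, at which 2 of the 2 values shown sit. Going by the values given here, the one measured step, a step that the two limits leave unreadable from compound 1 to compound 2, cannot be read in size for that reason, so it gives no direction to carry forward.

Compound 3 `CCCn1c(=O)[nH]c2nc(-c3ccc(S(=O)(=O)N4CCN(Cc5ccc(Br)c(F)c5)CC4)cc3)[nH]c2c1=O` differs from compound 2 by 4-bromo-3-fluorobenzyl in place of 4-methylphenyl on an amine nitrogen in a ring. Among the compounds with values here, no measured step covers this change; the only change seen exchanges one aryl group for another on the same ring nitrogen and leaves both values at the limit.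

With nothing to move it, compound 3 is expected to stay near the limit of this assay, estimated at 2000 nM with a range of 500 nM to 8000 nM, which means an expected step that the limit leaves unreadable from compound 2 to compound 3.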

Compound 3, inhibition constant: > 1000 nM
Compound 3 ended at the assay's limit; the forecaster's own chance of this, stated with the estimate: 70%; the middle value lies beyond the limit too.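

In this assay compound 3 gives > 1000 nM, a limit of the assay and not a number, so the steps from compound 1 and compound 2 to compound 3 cannot be read: the limit of > 1000 nM in this assay, at which 3 of the 3 values shown sit.

The compounds shown leave open whether any group on the ring nitrogen gives a readable value in this assay.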